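The compounds below may be only part of what the source reports. "The series", "measured", "known", "first", "only" and "open" are said of these compounds alone.

Measured compounds:
compound 1, `CCCCNc1ccc([N+](=O)[O-])cc1S(N)(=O)=O`, gives 4.7%
compound 2, `CCCCCCNc1ccc([N+](=O)[O-])cc1S(N)(=O)=O`, gives 3.8%
compound 3, `CCCCNc1ccc(C(=O)O)cc1S(=O)(=O)N(C)C`, gives 15.6%

All three were run in an assay on HEK293 cells for inhibition of solute carrier family 12 member 2 (Homo sapiens), read by fluorescence, with a stated time of 30 min, tested at 100 uM; on this read-out lower numbers stand for a weaker effect and higher numbers for a stronger effect at the one concentration tested. Compound 1 and compound 2 differ by ethyl in place of hydrogen on a saturated chain carbon, four bonds along the chain from a nitrogen on an aromatic ring, and the step recorded is a number 0.9 percentage points lower from compound 1 to compound 2 (within the scatter), so the two values cannot be told apart here. Compound 3 stands highest of the three numbers; its gap to compound 1 and its gap to compound 2 are both beyond the scatter. The difference between the core of compound 3 and the core of compound 1 is not broken down here.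

Compound 4, `CCCCCCNc1ccc(C(=O)O)cc1S(=O)(=O)N(C)C`, has not yet been measured in this assay. It differs from compound 3 by ethyl in place of hydrogen on a saturated chain carbon, four bonds along the chain from a nitrogen on an aromatic ring, the same change, at the same place, as that from compound 1 to compound 2. Only one earlier occurrence of this change is available, and it stayed flat. The step from compound 3 to compound 4 is therefore expected to be a number 1.6 percentage points lower from compound 3 to compound 4 (within the scatter), resting on compound 1 and compound 2, whose step a number 0.9 percentage points lower from compound 1 to compound 2 (within the scatter) lay within the scatter. Compound 4 is estimated at 14%, with a likely range from 4% to 24%.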

Compound 4, a percentage reported as inhibition, at one concentration (the size of the read-out at that concentration, not a potency): 19.8%
Compound 4: middle estimate off by 5.8 percentage points, on the low side, and the stated range covers the measured number.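

In this assay, ethyl in place of hydrogen on the saturated chain carbon gives a step on the core of compound 3 that reads a number 4.2 percentage points higher from compound 3 to compound 4 (within the scatter), so this occurrence also stays inside the usual variation. Set beside the earlier occurrence, the change carries from one core to the other with no difference that can be told apart: the same change on two cores in this assay, a number 0.9 percentage points lower (within the scatter) from compound 1 to compound 2 and a number 4.2 percentage points higher (within the scatter) from compound 3 to compound 4, 5.1 percentage points apart, within the scatter of two such steps

Among these compounds, this shows only that the change left the read-out flat on these two cores, at the one concentration tested; the opposite directions of the two steps mean nothing, and two pairs cannot show that the change would stay flat on any other core, nor do they say anything about potency.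

From the compounds shown here alone, a longer chain, or a chain carrying an amine, remains open on both cores. So does which of the several differences between the core of compound 1 and the core of compound 3 accounts for the gap between their values.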